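Removing the carboxyethyl chain from a tricyclic lactone

The compounds below may be only part of what the source reports. "The series", "measured", "known", "first", "only" and "open" are said of these compounds alone.

Measured compounds:
Compound 1, `CC1(C)[C@@H]2CC3=N[C@@H](CCC(=O)O)C(=O)O[C@@]3(C)[C@H]1C2`: 38000 nM
Compound 2, `CC1(C)[C@H]2CC[C@]1(C)[C@H]1OC(=O)CN=C21`: 135000 nM
Compound 3, `CC1(C)[C@H]2CC3=N[C@H](CCC(=O)O)C(=O)O[C@]3(C)[C@@H]1C2`: 34000 nM

Of the compounds shown here, three have been read in a functional assay on MCF7 cells (Homo sapiens) for antiproliferative activity, read by sulforhodamine B assay, with a stated time of 48 h; on this read-out lower numbers stand for stronger inhibition and higher numbers for weaker inhibition. Compound 1 stands second highest of the three numbers; compound 3 lies nearest to it, and compound 2 lies furthest from it. For the measured compounds named here, the only step between compounds differing in one place is a 1.1-fold lower number from compound 1 to compound 3 (0.05 log units; within the scatter), resting on (the fact that compounds 1 and 3 differ only in the configuration as drawn). For compound 2, which has a smaller core and no chain, only its own value and that of compound 1 can be set side by side, and compound 2 gives the higher number.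

Compound 4, `CC1(C)[C@@H]2CC3=NCC(=O)O[C@@]3(C)[C@H]1C2`, has not yet been measured. It differs from compound 1 in hydrogen in place of 2-carboxyethyl on a saturated ring carbon. Going by the values given here, no measured step removes this chain on the shared core, so the mirror-image step gives no guide to its size. Compound 4 is therefore estimated at 70000 nM, within 20000 nM to 250000 nM, an expected step of a 1.8-fold higher number from compound 1 to compound 4 (0.27 log units; within the scatter) toward a higher number.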

Compound 4, half-maximal inhibitory concentration: 22000 nM
For compound 4 the middle estimate is 3.2-fold (0.50 log units) above the measured one; the range from low to high includes it.
By their numbers in this assay, from the lowest: compounds 4, 3 and 1 (each within the scatter of the next); then compound 2.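

In this assay, taking away the chain gives a 1.7-fold lower number from compound 1 to compound 4 (0.24 log units; within the scatter), and this is the only step shown at this saturated ring carbon next to the ring nitrogen. On the core of compound 1, the assay therefore does not separate the compound bearing 2-carboxyethyl from the one bearing hydrogen, so the number does not depend on this chain to any extent the read-out can resolve. Nothing available explains why the chain makes so little difference.

The compounds shown leave open whether an amine, a carboxylic acid held directly on this carbon or a longer chain would give a number beyond the scatter from that of compound 4. They also leave open whether hydrogen in place of 2-carboxyethyl would read the same way on the mirror-image core of compound 3.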